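The source may hold more compounds than are shown below. What is called first, only, known or untested is meant among the compounds shown, and "the series" means these compounds.

The study contains two measured compounds and one not yet measured. Compound 1 `COc1ccc(OC)c(/C=C/c2nnc(Nc3ccc(Cl)cc3)o2)c1` was tested in a functional assay on EKVX cells (Homo sapiens) for antiproliferative activity, read by sulforhodamine B assay, with a stated time of 48 h; on this read-out higher numbers stand for lower toxicity in this test and lower numbers for higher toxicity in this test. For compound 1 the result is only a limit of the test, > 100000 nM. Compound 2 `COc1ccc(OC)c(/C=C/C(=O)N/N=C/c2ccc(Cl)cc2)c1` was tested in this assay as well. For compound 2 the result is again a limit, > 100000 nM. Thus compound 2 stands at the limit of > 100000 nM in this assay, at which 2 of the 2 values shown sit, with no numerical value to set it apart from compound 1. Compound 3 `COc1ccc(OC)c(/C=C/C(=O)N/N=C/c2ccccc2)c1` is the one still to be measured. It differs from compound 2 by hydrogen in place of chloro on an aromatic carbon. Going by the values given here, no step between two measured compounds is available in this assay, so the size of this change can only be guessed. Because both measured compounds sit at the limit of > 100000 nM in this assay, at which 2 of the 2 values shown sit, the expected step from one to the other is none beyond the scatter, in no particular direction, and the expected step is a number no higher from compound 2 to compound 3 (the limit leaves the size open). The value expected for compound 3 is 100000 nM, within 30000 nM to 300000 nM.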

Compound 3, concentration lethal to 50% of the cells: > 100000 nM
Compound 3 gave a limit, no number; the forecaster's own chance of this, stated with the estimate: 75%; the middle value lies on the limit itself.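

No step can be read between compound 2 and compound 3 in this assay, since each gives only a limit: the limit of > 100000 nM in this assay, at which 3 of the 3 values shown sit.

The compounds shown leave open whether 4-chlorophenyl and phenyl differ at all in this test, and how far any compound lies from that limit.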